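This account rests on a few compounds, and the source may have more. Where it says the series, first, only, none or still open, it means among the compounds named here.

Compound 3 `COc1cc2c(Oc3ccc(NC(=O)c4cc(-c5ccccc5)nc5ccc(F)cc45)cc3F)ccnc2cc1OCCCN1CCCCC1` gives 120 nM in a functional assay on HT-29 cells (Homo sapiens) for cytotoxicity, read by MTT assay, with a stated time of 72 h (a higher number here means a weaker inhibitor, a lower number a stronger inhibitor), the lowest of the three numbers measured: compound 1 `COc1cc2c(Oc3ccc(NC(=O)c4cc(-c5ccccc5)nc5ccccc45)cc3F)ccnc2cc1OCCCN1CCCCC1` gives 530 nM, and compound 2 `COc1cccc(-c2cc(C(=O)Nc3ccc(Oc4ccnc5cc(OCCCN6CCCCC6)c(OC)cc45)c(F)c3)c3ccccc3n2)c1` gives 1740 nM. Compound 4 `COc1cccc(-c2cc(C(=O)Nc3ccc(Oc4ccnc5cc(OCCCN6CCCCC6)c(OC)cc45)c(F)c3)c3cc(F)ccc3n2)c1` differs from compound 3 by methoxy in place of hydrogen on an aromatic carbon. The same change has been measured once already, in a 3.3-fold higher number from compound 1 to compound 2 (0.52 log units; beyond the scatter). The other measured step, a 4.4-fold lower number from compound 1 to compound 3 (0.65 log units; beyond the scatter), concerns the fluoro group that compound 3 and compound 4 both carry, so it does not bear directly on this change. Compound 4 is therefore expected to sit higher, with a step of about a 3.3-fold higher number from compound 3 to compound 4 (0.52 log units; beyond the scatter). Compound 4 is expected to give roughly 400 nM, with a likely range from 180 nM to 900 nM.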

Compound 4, half-maximal inhibitory concentration: 2500 nM
For compound 4 the middle estimate is 6.3-fold (0.80 log units) below the measured one; measured number outside the range, above it.
By their numbers in this assay, from the lowest: compound 3; then compound 1; then compounds 2 and 4 (each within the scatter of the next).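

The methoxy step is not a fixed cost: with the fluoro group on the core it comes to a 21-fold higher number from compound 3 to compound 4 (1.32 log units; beyond the scatter), so its size depends on what else the molecule carries: the same change on two cores in this assay, a 3.3-fold higher number (0.52 log units; beyond the scatter) from compound 1 to compound 2 and a 21-fold higher number (1.32 log units; beyond the scatter) from compound 3 to compound 4, 6.3-fold (0.80 log units) apart, beyond the scatter of two such steps. Read the other way, the fluoro group gives no step beyond the scatter once the 3-methoxyphenyl is present, at a 1.4-fold higher number from compound 2 to compound 4 (0.16 log units; within the scatter): the same change on two cores in this assay, a 4.4-fold lower number (0.65 log units; beyond the scatter) from compound 1 to compound 3 and a 1.4-fold higher number (0.16 log units; within the scatter) from compound 2 to compound 4, 6.3-fold (0.80 log units) apart, beyond the scatter of two such steps. The two changes therefore do not simply add up across these four compounds.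

Why they fail to add stays open, since two pairs cannot explain it. Also open, on these data alone, is whether a hydroxy group or an amine in place of the methoxy would depend on the fluoro group in the same way.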